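The compounds below may be only part of what the source reports. "The series", "measured", "known", "first", "only" and "open" are said of these compounds alone.

Measured so far in an ADME assay on a cell-free system (plasma, Homo sapiens) for metabolic stability; a higher number here means that the compound lasts longer, a lower number that the compound disappears faster:
Compound 1 `CNc1[nH]c(=O)n(O)c(=O)c1C(=O)NCc1ccccc1`: > 24 h
Compound 2 `CCNc1[nH]c(=O)n(O)c(=O)c1C(=O)NCc1ccccc1`: > 24 h
Compound 3 `CCNc1[nH]c(=O)n(O)c(=O)c1C(=O)NCc1cccc(Cl)c1F`: > 24 h

Compound 3 gives > 24 h, which is a limit of the assay and not a number. It is in the same position as the other two compounds: the limit of > 24 h in this assay, at which 3 of the 3 values shown sit.

Compound 4 `CCNc1[nH]c(=O)n(O)c(=O)c1C(=O)NCc1ccc(F)cc1` keeps the shared core and alters a single group: 4-fluorophenyl in place of 3-chloro-2-fluorophenyl on a saturated chain carbon bound to an amide-type nitrogen. In words, 4-fluorophenyl stands in place of 3-chloro-2-fluorophenyl on a saturated chain carbon bound to an amide-type nitrogen.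

Two measured steps can be consulted. The first, a step that the two limits leave unreadable from compound 1 to compound 2, lies at a different place, on a saturated chain carbon bound to a nitrogen on an aromatic ring. Closer to the new change is a step that the two limits leave unreadable from compound 2 to compound 3, at the same place, where 3-chloro-2-fluorophenyl stands in place of phenyl. Neither step has a readable size, so the data give no measured effect of changing this group.

Compound 4 is expected to sit with compound 3 because of the limit of > 24 h in this assay, at which 3 of the 3 values shown sit. No step beyond the usual scatter is expected in this assay, and a limit is again the most likely report. The estimated step is a step that the limit leaves unreadable from compound 3 to compound 4. For compound 4 the estimated half-life is 30 h, with an expected range from 20 h to 60 h.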

Compound 4, half-life: > 24 h
Compound 4 gave a limit, no number (the forecaster's own chance of this, stated with the estimate: 90%); the middle value lies beyond the limit too.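

In this assay compound 4 gives > 24 h, which is a limit of the assay and not a number. Compound 2 and compound 3 also sit at a limit, so neither step to compound 4 can be read: the limit of > 24 h in this assay, at which 4 of the 4 values shown sit.

The compounds shown leave open how long each one actually lasts, and whether any of these changes of group alters that.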